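The source may report more compounds than this note shows. Statements on the series, on what has been measured and on what is new or still open speak of the compounds shown alone.

Compound 1 `Cc1c(-c2cc(Cl)cc(Cl)c2)c(C(=O)O)nn1-c1nc(-c2cnn(C)c2)c(SC(C)C)s1` — in a functional assay on BJAB cells (Homo sapiens) for antiproliferative activity, with a stated time of 4 days (on this read-out higher numbers stand for an effect only at larger amounts of compound and lower numbers for an effect already at smaller amounts), compound 1 gives "not active" (no number reported).
Compound 2 `Cc1nn(-c2nc(-c3ccc(Cl)c(Cl)c3)c(SC(C)C)s2)c(C(=O)O)c1-c1ccc(Cl)cc1` — in this assay compound 2 gives 2500 nM.
Compound 3 `Cc1nn(-c2nc(-c3ccc(Cl)c(Cl)c3)c(SC(C)C)s2)c(C(=O)O)c1-c1cccc(C(F)(F)F)c1` — in this assay compound 3 gives 22000 nM.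

Compound 1 stands apart from the other two: in this assay it carries no number at all, only the report of no activity, so it cannot be placed on the scale that compound 2 and compound 3 occupy. Compound 4 `Cc1c(-c2cc(Cl)cc(Cl)c2)c(C(=O)O)nn1-c1nc(-c2ccc3nccn3c2)c(SC(C)C)s1` differs from compound 1 in one place: a group of 9 heavy atoms (7 carbon, 2 nitrogen; one five-membered aromatic ring with 2 hetero atoms, one six-membered aromatic ring with 1 hetero atom) in place of a group of 6 heavy atoms (4 carbon, 2 nitrogen; one five-membered aromatic ring with 2 hetero atoms), on an aromatic carbon. For the measured compounds named here, the only measured step, an 8.8-fold higher number from compound 2 to compound 3 (0.94 log units; beyond the scatter), concerns a different position of the shared core and says nothing about the group exchanged here, so no measured step bears directly on the change from compound 1 to compound 4. What remains is the range spanned by compound 2 and compound 3 in this assay, both weak, and the absence of a number for compound 1. Compound 4 is therefore expected to sit in that weak region, with a real chance that this assay again reports no number; the estimate is 15000 nM, ranging from 3000 nM to 60000 nM.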

Compound 4, half-maximal effective concentration: "not active" (no number reported)
For compound 4 the study gives words and no number; the estimate stays without a comparison.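

Compound 1 and compound 4 both come without a number in this assay, so no step can be read between them, and nothing shown here offers an explanation. The compounds shown leave open whether exchanging the 1-methyl-1H-pyrazol-4-yl group has any effect on this read-out.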